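The source may hold more compounds than are shown below. What is called first, only, known or untested is meant among the compounds shown, and "the series" means these compounds.

Of the compounds shown here, three built on one shared core have been tested in an ADME assay on MCF-10A cells (Homo sapiens) for cytotoxicity, read by MTT assay, with a stated time of 48 h; a higher number here means a weaker inhibitor, a lower number a stronger inhibitor. Compound 1 `COc1cc2cc(C(=O)NCc3ccc(F)cc3)c(=O)oc2cc1OCCCOc1no[n+]([O-])c1S(=O)(=O)c1ccccc1` gives 8460 nM in this assay. Compound 2 `COc1ccc(CNC(=O)c2cc3cc(OC)c(OCCCOc4no[n+]([O-])c4S(=O)(=O)c4ccccc4)cc3oc2=O)cc1` gives 5950 nM. Compound 3 `COc1cc2cc(C(=O)Nc3ccccc3)c(=O)oc2cc1OCCCOc1no[n+]([O-])c1S(=O)(=O)c1ccccc1` gives 9670 nM, which is the largest of the three numbers, although the steps that separate it from the other two are both within the scatter: a 1.1-fold higher number from compound 1 to compound 3 (0.06 log units; within the scatter) and a 1.6-fold higher number from compound 2 to compound 3 (0.21 log units; within the scatter). Compound 4 `COc1cc2cc(C(=O)NCCCc3ccccc3)c(=O)oc2cc1OCCCOc1no[n+]([O-])c1S(=O)(=O)c1ccccc1` is not yet measured. It differs from compound 3 in one place only: 3-phenylpropyl in place of phenyl on an amide-type nitrogen. The two measured steps that bear on this change are the ones that also exchanged the group on the amide-type nitrogen, from compound 1 to compound 3 and from compound 2 to compound 3, and neither moved the number beyond the scatter. The step from compound 3 to compound 4 is therefore expected to be no larger than the scatter, a 1.1-fold lower number from compound 3 to compound 4 (0.06 log units; within the scatter), with no direction to call. Compound 4 is expected to give about 8500 nM in this assay, with a likely range from 4000 nM to 18000 nM.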

Compound 4, half-maximal inhibitory concentration: 5330 nM
The estimate for compound 4 lay 1.6-fold (0.20 log units) above the measured number; the measured number falls inside the stated range.
By their numbers in this assay, from the lowest: compounds 4, 2, 1 and 3 (each within the scatter of the next).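

The earlier changes on the amide-type nitrogen involved only phenyl, 4-fluorobenzyl and 4-methoxybenzyl, whereas 3-phenylpropyl carries the aromatic ring on a longer saturated chain, and this change still gives only a 1.8-fold lower number from compound 3 to compound 4 (0.26 log units; within the scatter). Set against the two substituted benzyl groups, the same chain gives a 1.1-fold lower number from compound 2 to compound 4 (0.05 log units; within the scatter) and a 1.6-fold lower number from compound 1 to compound 4 (0.20 log units; within the scatter). Across all four compounds in this assay, then, this position has not yet shifted the number beyond the scatter, even with the longer chain in place.

As far as these compounds go, whether an amine or a carboxylic acid on this chain, or a chain longer than propyl, would shift the number beyond the scatter remains open. Nothing available explains why the four numbers stay so close together.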